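Working notes: chloro in place of trifluoromethyl, compound 3

A few compounds are considered here, and "the series" means these few. Any claim that something is new, unique, unknown or untested is made for them only; others in the source may bear on it.

In a functional assay on A549 cells (Homo sapiens) for cytotoxicity, read by MTT assay, with a stated time of 68 h (on this read-out lower numbers stand for stronger inhibition and higher numbers for weaker inhibition), compound 1 `Nc1cccc(-c2cccc(NC(=O)C(Cl)Cl)c2)c1` gives 50000 nM and compound 2 `O=C(Nc1cccc(-c2cccc(C(F)(F)F)c2)c1)C(Cl)Cl` gives 18500 nM as the lower of the two numbers. Going by the values given here, the one measured step of a 2.7-fold lower number from compound 1 to compound 2 (0.43 log units; beyond the scatter) is modest and does not involve chloro. Compound 3 `O=C(Nc1cccc(-c2cccc(Cl)c2)c1)C(Cl)Cl` differs from compound 2 by chloro in place of trifluoromethyl on an aromatic carbon as chloro in place of trifluoromethyl on an aromatic carbon. With no measured chloro comparison, the expected change a 1.2-fold higher number from compound 2 to compound 3 (0.08 log units; within the scatter) in this assay is small, within the scatter and without a firm direction. The estimate for compound 3 is 22000 nM with an expected range of 11000 nM to 42000 nM in this series.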

Compound 3, half-maximal inhibitory concentration: 21400 nM
Beside the measured number, compound 3's estimate is 1.0-fold (0.01 log units) above it, within the range that was stated.
By their numbers in this assay, from the lowest: compounds 2 and 3 (each within the scatter of the next); then compound 1.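

In this assay, chloro and trifluoromethyl on this aromatic carbon are not told apart (a 1.2-fold higher number from compound 2 to compound 3 (0.06 log units; within the scatter)). Chloro in place of amino also moves the number (a 2.3-fold lower number from compound 1 to compound 3 (0.37 log units; beyond the scatter)), so the step away from amino is no longer seen with trifluoromethyl alone. No measurement at hand bears on why the numbers fall this way.

As far as these compounds go, whether a methoxy group or a carboxylic acid on this carbon would stay level with chloro and trifluoromethyl or sit with amino remains open. Also open, from the compounds shown here alone, is whether these steps hold when another part of the shared core changes.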